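Carbonyl aryl swap from compound 3 to compound 4

The source may report more compounds than this note shows. Statements on the series, on what has been measured and on what is new or still open speak of the compounds shown alone.

Measured in a functional assay on DU-145 cells (Homo sapiens) for inhibition, read by trypan blue exclusion, with a stated time of 96 h; on this read-out lower numbers stand for stronger inhibition of growth and higher numbers for weaker inhibition of growth
- compound 1 `O=C(/C(=C\c1ccc(O)c([N+](=O)[O-])c1)SCc1ccc(Br)cc1)c1ccc(Br)cc1` gives 10000 nM
- compound 2 `O=C(/C(=C\c1ccc(O)c([N+](=O)[O-])c1)Sc1ccccc1Br)c1ccc(Br)cc1` gives 10000 nM
- compound 3 `O=C(/C(=C\c1ccc(O)c([N+](=O)[O-])c1)Sc1ccc(Br)cc1)c1c(F)c(F)c(F)c(F)c1F` gives 1000 nM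

Compound 3 has the lowest number of the three, and compound 1 and compound 2 both lie above it beyond the scatter. The move to compound 4 `O=C(/C(=C\c1ccc(O)c([N+](=O)[O-])c1)Sc1ccc(Br)cc1)c1ccc(Br)cc1` is 4-bromophenyl in place of 2,3,4,5,6-pentafluorophenyl on a carbonyl carbon and puts 4-bromophenyl in place of 2,3,4,5,6-pentafluorophenyl on a carbonyl carbon. Among the measured compounds shown here, the only measured step, no change at the digits printed from compound 1 to compound 2 (within the scatter), changes the group on a sulfur, so no measured pair isolates this swap. Compound 2 at 10000 nM carries 4-bromophenyl on that carbonyl carbon, which points to weaker inhibition of growth. The expected move is a 3.0-fold higher number from compound 3 to compound 4 (0.48 log units; beyond the scatter) in this assay, a rise in the number. Compound 4 is estimated at 3000 nM, with an expected range of 800 nM to 10000 nM as its ends.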

Compound 4, concentration for 50% growth inhibition: 1000 nM
Estimate against measurement, compound 4: 3.0-fold (0.48 log units) above, and the stated range covers the measured number.
By their numbers in this assay, from the lowest: compounds 3 and 4 (each within the scatter of the next); then compounds 1 and 2 (each within the scatter of the next).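

In this assay the carbonyl carbon accepts 4-bromophenyl in place of 2,3,4,5,6-pentafluorophenyl, with no change at the digits printed from compound 3 to compound 4 (within the scatter) for this swap. The group on the sulfur carries the larger steps in this set: a 10-fold lower number from compound 2 to compound 4 (1.00 log units; beyond the scatter) for 4-bromophenyl in place of 2-bromophenyl, and a 10-fold lower number from compound 1 to compound 4 (1.00 log units; beyond the scatter) for 4-bromophenyl in place of 4-bromobenzyl. No supporting measurement gives a reason for these results.

Open, going by these compounds, is whether the carbonyl carbon also accepts a saturated ring such as cyclohexyl or a phenyl bearing an amine. Also open, on these data alone, is how a carboxylic acid or a longer chain on the sulfur would compare with 4-bromophenyl there.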